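The source may report more compounds than this note shows. Statements on the series, on what has been measured and on what is new or still open speak of the compounds shown alone.

Measured so far in a functional assay on MCF7 cells (Homo sapiens) for cytotoxicity, read by MTT assay, with a stated time of 72 h; on this read-out higher numbers stand for weaker inhibition and lower numbers for stronger inhibition:
compound 1 `CNC(=O)c1cc(Oc2ccc(NC(=O)c3nn(-c4ccccc4OC(F)(F)F)c(=O)cc3C)cc2F)ccn1` — a limit, > 40000 nM
compound 2 `CNC(=O)c1cc(Oc2ccc(NC(=O)c3nn(-c4ccc(C)cc4)c(=O)cc3C)cc2F)ccn1` — 8380 nM
compound 3 `Cc1cc(=O)n(-c2ccccc2C(F)(F)F)nc1C(=O)Nc1ccc(Oc2ncnc3ccsc23)cc1` — 5550 nM

Compound 1 returns only a limit of the assay, (the limit of > 40000 nM in this assay, at which 1 of the 3 values shown sits). Compound 3 sits at the low end of the numbers shown, but its gap to compound 2 lies within the scatter, so the two are not distinguished.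

Compound 4 `Cc1cc(=O)n(-c2ccc(F)cc2)nc1C(=O)Nc1ccc(Oc2ncnc3ccsc23)cc1` differs from compound 3 in one place: 4-fluorophenyl in place of 2-(trifluoromethyl)phenyl on an aromatic nitrogen. Going by the values given here, the one measured step of related character is an at least 4.7-fold lower number from compound 1 to compound 2 (0.67 log units; beyond the scatter), where a group on the same aromatic nitrogen also went from 2-(trifluoromethoxy)phenyl to 4-methylphenyl. That step is at least modest in size, though its full extent is open since compound 1 yields only a limit. The expectation for compound 4 in this assay is therefore a lower number than for compound 3, of modest size, a 2.8-fold lower number from compound 3 to compound 4 (0.44 log units; beyond the scatter). Compound 4 is expected at 2000 nM, in the range 600 nM to 7000 nM.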

Compound 4, half-maximal inhibitory concentration: 4400 nM
For compound 4 the middle estimate is 2.2-fold (0.34 log units) below the measured one; measured number inside the range.
By their numbers in this assay, from the lowest: compounds 4, 3 and 2 (each within the scatter of the next). At a limit, above all of these: compound 1.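

Only the aromatic nitrogen substituent changes here, and in this assay 4-fluorophenyl in place of 2-(trifluoromethyl)phenyl gives a 1.3-fold lower number from compound 3 to compound 4 (0.10 log units; within the scatter), so on this core the swap does not separate the two compounds. Going by these compounds alone, the readable shift at this nitrogen on the other core, an at least 4.7-fold lower number from compound 1 to compound 2 (0.67 log units; beyond the scatter), rests on a limit of the assay and has no counterpart here, so a change of aryl group at this position does not by itself give a shift beyond the scatter. Nothing measured here offers a cause for the flat step.

Open, from the compounds shown here alone, is whether an amine or a carboxylic acid on the phenyl ring, or a longer chain in place of that ring, would move the number at this nitrogen. Also open is how one and the same aryl group behaves on both cores, as no such pair is among the compounds shown.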